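Moving a Pyridine Nitrogen and Watching Solubility

The compounds below may be only part of what the source reports. "The series", "measured", "known", "first", "only" and "open" are said of these compounds alone.

Four compounds share one core and differ in two places: the group on the amide side and the pyridine ring carried on a single chain carbon. Compound 1 `O=C(Nc1ncc(Cc2ccccn2)s1)C1CCCCC1` holds a pyridin-2-yl group; in a physicochemical assay for solubility, at pH 7 (a lower number here means a less soluble compound, a higher number a more soluble compound), compound 1 gives 340 ug/mL. Compound 2 `O=C(Nc1ncc(Cc2ccncc2)s1)C1CCCCC1` differs from it in one way only: pyridin-4-yl in place of pyridin-2-yl on a saturated chain carbon bound to an aromatic carbon. In this assay compound 2 gives 350 ug/mL, and the step of a 1.0-fold higher number from compound 1 to compound 2 (0.01 log units; within the scatter). Compound 3 `O=C(CCC1CCCCC1)Nc1ncc(Cc2ccccn2)s1` keeps the pyridin-2-yl group of compound 1 but changes the amide side; the difference between the two cores is not broken down here. In this assay compound 3 gives 40 ug/mL, the lowest of the three numbers, and its distance from compound 1 and from compound 2 lies beyond the scatter.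

Compound 4 `O=C(CCC1CCCCC1)Nc1ncc(Cc2ccncc2)s1` has not been measured. It stands to compound 3 as compound 2 stands to compound 1: pyridin-4-yl in place of pyridin-2-yl on a saturated chain carbon bound to an aromatic carbon. The place of the change is the same in both pairs, so this is the same change made on a less soluble core. The expectation for compound 4 rests on compound 1 and compound 2, because the step of a 1.0-fold higher number from compound 1 to compound 2 (0.01 log units; within the scatter) stayed within the scatter. The step expected from this change is no change at the digits printed from compound 3 to compound 4 (within the scatter). Compound 4 is therefore estimated at 40 ug/mL, with a likely range from 20 ug/mL to 80 ug/mL.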

Compound 4, solubility: 40 ug/mL
Beside the measured number, compound 4's estimate shows no gap at the digits printed; low and high end bracket the measured number.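

In this assay, placing pyridin-4-yl where pyridin-2-yl stood on the core of compound 3 gives no change at the digits printed from compound 3 to compound 4 (within the scatter), and the same exchange on the core of compound 1 gave a 1.0-fold higher number from compound 1 to compound 2 (0.01 log units; within the scatter), so in both pairs the numbers stay within the scatter, even though compound 1 gives 340 ug/mL and compound 3 gives only 40 ug/mL. This shows that, across these two cores, a step measured on the more soluble core correctly described the step on the less soluble one, but two pairs are a small sample and do not establish a rule for every core in the series. Nothing measured here explains why the two pyridine groups give matching numbers in each pair.

The compounds shown leave open whether the exchange would still read the same if the cyclohexyl group on the amide side gave way to an amine or a carboxylic acid, or if a longer chain separated that ring from the carbonyl. They also leave open whether a different group on the saturated chain carbon, such as a plain phenyl ring, would match either pyridine.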